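The source may hold more compounds than are shown below. What is called first, only, known or untested is meant among the compounds shown, and "the series" means these compounds.

Measured compounds:
- compound 1 `CC(C)Cc1ccc2c(NCCCNCc3ccco3)ccnc2c1`: 23 10^-6 cm/s
- compound 2 `COc1ccc(F)cc1CNCCCNc1ccnc2cc(CCc3ccccc3)ccc12`: 23 10^-6 cm/s
- compound 3 `COc1ccc(F)cc1CNCCCNc1ccnc2cc(CC(C)C)ccc12`: 23 10^-6 cm/s

In an ADME assay for permeability, using PAMPA, with a stated time of 30 min, at pH 7.4 (on this read-out lower numbers stand for lower permeability and higher numbers for higher permeability), compound 1 gives 23 10^-6 cm/s and stands level with compound 2 and compound 3, all three agreeing within the scatter. The two steps that connect them are small: no change at the digits printed from compound 1 to compound 3 (within the scatter) and no change at the digits printed from compound 2 to compound 3 (within the scatter). The unmeasured compound 4 `Fc1ccc(Cc2ccc3c(NCCCNCc4ccco4)ccnc3c2)cc1` differs from compound 1 at a single place, (4-fluorophenyl in place of isopropyl on a saturated chain carbon bound to an aromatic carbon). The step from compound 2 to compound 3 is the one that bears on this change, since it swaps isopropyl and benzyl at the same saturated chain carbon bound to an aromatic carbon and left the read-out unchanged within the scatter; the change from compound 1 to compound 4 runs the other way, isopropyl to 4-fluorophenyl, at that same place. On that evidence the step of no change at the digits printed from compound 1 to compound 4 (within the scatter) is expected to lie within the scatter, with no direction beyond it. Compound 4 is therefore estimated at 23 10^-6 cm/s, in the range 12 10^-6 cm/s to 42 10^-6 cm/s.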

Compound 4, apparent permeability: 23 10^-6 cm/s
For compound 4 middle estimate and measured number coincide at the digits printed; measured number inside the range.
By their numbers in this assay, from the lowest: compounds 1, 2, 3 and 4 (each within the scatter of the next).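

In this assay, the exchange of isopropyl for 4-fluorophenyl on a saturated chain carbon bound to an aromatic carbon gives no change at the digits printed from compound 1 to compound 4 (within the scatter), so a fluorine-bearing aromatic ring at this place leaves the read-out level. The earlier evidence at this place, no change at the digits printed from compound 2 to compound 3 (within the scatter), came with 5-fluoro-2-methoxyphenyl on the chain carbon bound to the amine nitrogen, whereas the new step holds with furan-2-yl there. No measurement shown explains why the read-out stays level across this change.

All groups shown at this place are hydrocarbon or fluorinated aromatic groups, so the compounds leave open what an amine or a carboxylic acid there would do to the read-out. As far as these compounds go, whether a longer chain at the same place would shift the number beyond the scatter also remains open.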